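A few compounds are considered here, and "the series" means these few. Any claim that something is new, unique, unknown or untested is made for them only; others in the source may bear on it.

Compound 1 `CC(C)c1ccc(Nc2ccc(C(=O)C(Cl)Cl)cc2[N+](=O)[O-])cc1`: 1210 nM
Compound 2 `CC(C)(C)c1ccc(Nc2ccc(C(=O)C(Cl)Cl)cc2[N+](=O)[O-])cc1`: 1900 nM

Both values come from a functional assay on MCF7 cells (Homo sapiens) for inhibition, read by MTT assay, with a stated time of 72 h; on this read-out higher numbers stand for weaker inhibition and lower numbers for stronger inhibition. Among the measured compounds shown here, compound 2 has no clear rank on these numbers, as its only measured comparison falls within the scatter. That comparison, methyl in place of hydrogen on a saturated chain carbon bound to an aromatic carbon and two saturated chain carbons, is a 1.6-fold higher number from compound 1 to compound 2 (0.20 log units; within the scatter).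

Compound 3 `CC(C)(O)c1ccc(Nc2ccc(C(=O)C(Cl)Cl)cc2[N+](=O)[O-])cc1` carries its change at that same carbon: hydroxy in place of methyl on a saturated chain carbon bound to an aromatic carbon and two saturated chain carbons. In words, this is hydroxy in place of methyl, or tert-butyl to 1-hydroxy-1-methylethyl.

For the measured compounds named here, the one measured step at this carbon bears on the question only in part, since it brings in no hydroxy and no measured compound carries one. Its small size gives no ground for expecting a large step in this assay, so a change within the scatter is expected, with a slight lean towards a higher number. The expected change is a 1.4-fold higher number from compound 2 to compound 3 (0.14 log units; within the scatter). The estimate for compound 3 is 2600 nM, with the measurement expected between 900 nM and 7000 nM.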

Compound 3, half-maximal inhibitory concentration: 2980 nM
Compound 3: middle estimate off by 1.1-fold (0.06 log units), on the low side; the range from low to high includes it.
By their numbers in this assay, from the lowest: compounds 1, 2 and 3 (each within the scatter of the next, the first and the last beyond it).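

At the saturated chain carbon bound to an aromatic carbon and two saturated chain carbons, hydroxy is the first group shown to add a hydrogen-bond donor and a hydrogen-bond acceptor, and in this assay putting it in place of methyl gives a 1.6-fold higher number from compound 2 to compound 3 (0.20 log units; within the scatter) and so does not separate these two compounds. Hydroxy in place of hydrogen at the same carbon gives a 2.5-fold higher number from compound 1 to compound 3 (0.39 log units; beyond the scatter) and is the first step at this position to pass beyond the scatter, although it is only modest, so two steps that each lie within the scatter are joined here by a larger one between the compounds at either end. Nothing available here accounts for these numbers.

The compounds shown leave open whether an amine, a methoxy group or a carboxylic acid at this carbon would produce a larger step in this assay than hydroxy does. They also leave open whether a longer chain bearing the hydroxy group, such as 2-hydroxyethyl, would give a number close to those of compound 2 and compound 3.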